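The source may report more compounds than this note shows. Statements on the series, on what has been measured and on what is new or still open speak of the compounds shown alone.

Measured compounds:
Compound 1, `CC(=O)c1ccc(NC(=O)C(C(C)C)N(C(=O)c2ccccc2)S(=O)(=O)c2ccc(C)cc2)cc1`: 22.7%
Compound 2, `CC(=O)c1ccc(NC(=O)C(CC(C)C)N(C(=O)c2ccccc2)S(=O)(=O)c2ccc([N+](=O)[O-])cc2)cc1`: 54.2%
Compound 3, `CCC(C)C(C(=O)Nc1ccc(C(C)=O)cc1)N(C(=O)c1ccccc1)S(=O)(=O)c1ccc([N+](=O)[O-])cc1`: 31.7%

In a functional assay for inhibition, read by spectrophotometry, with a stated time of 20 min, tested at 2 mg/mL (on this read-out higher numbers stand for a stronger effect at the one concentration tested and lower numbers for a weaker effect), compound 3 stands second highest of the three. Its nearest neighbour is compound 1, whose number is lower by an amount within the scatter, so the two cannot be ordered; compound 2 lies further off, higher by an amount beyond the scatter, as the step of a number 22.5 percentage points lower from compound 2 to compound 3 (beyond the scatter) records.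

Compound 4, `CC(=O)c1ccc(NC(=O)C(C(C)C)N(C(=O)c2ccccc2)S(=O)(=O)c2ccc([N+](=O)[O-])cc2)cc1`, is not yet measured. It differs from compound 3 in one place: hydrogen in place of methyl on a saturated chain carbon, three bonds along the chain from an amide-type nitrogen and a carbonyl carbon. Going by the values given here, the only measured step on this chain is a number 22.5 percentage points lower from compound 2 to compound 3 (beyond the scatter), which is modest. The same isopropyl group as in compound 4 is carried by compound 1, which gives 22.7%, close to compound 3. Among the compounds with values here, no step within the scatter or beyond it can be firmly expected here; a small drop or no change is the likeliest outcome.

Compound 4 is therefore expected to give 27%, in a range from 12% to 45%. That estimate means a number 4.7 percentage points lower from compound 3 to compound 4 (within the scatter).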

Compound 4, a percentage reported as inhibition, at one concentration (the size of the read-out at that concentration, not a potency): 29.8%
Compound 4: middle estimate off by 2.8 percentage points, on the low side, and the stated range covers the measured number.
By their numbers in this assay, from the lowest: compounds 1, 4 and 3 (each within the scatter of the next); then compound 2.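

Taking away the methyl, which turns sec-butyl into isopropyl, leaves the number in this assay unchanged within the scatter (a number 1.9 percentage points lower from compound 3 to compound 4 (within the scatter)), so these two chains cannot be told apart here, while isopropyl, like sec-butyl, stands clearly apart from isobutyl (a number 24.4 percentage points lower from compound 2 to compound 4 (beyond the scatter)). Going by these compounds alone, the result also gives the first single-place reading of the group on the aromatic carbon: with the isopropyl chain held constant, nitro in place of methyl makes no change beyond the scatter (a number 7.1 percentage points higher from compound 1 to compound 4 (within the scatter)). No measurement shown here explains why isobutyl stands apart from the other two chains.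

On these data alone, it remains open how a straight n-butyl chain or a benzyl group on that saturated chain carbon would compare with isobutyl. As far as these compounds go, it is equally open whether an amine or a methoxy group in place of nitro on the aromatic carbon would change the number, with either the isopropyl or the isobutyl chain.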